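A few compounds are considered here, and "the series" means these few. Any claim that something is new, unique, unknown or untested is made for them only; others in the source may bear on it.

Among the measured compounds shown here, compound 1 `N#CC1=C(NCN2CCCC2)N(c2ccccc2)C(=O)N2CCCCC(N3CCCC3)C12` gives 26.6% in a functional assay on the whole organism (strain albino) for inhibition, with Rattus norvegicus as the target, read by paw edema, with stated times of 1 h and 2 h, at a dose of 20 mmol/kg by the intraperitoneal route (a lower number here means less inhibition, a higher number more inhibition at the dose given (going by the name of the read-out)), which is the lowest of the three numbers measured so far. Compound 3 `N#CC1=C(NCN2CCCCC2)N(c2ccccc2)C(=O)N2CCCCC(N3CCCC3)C12` gives 36.9% in this assay, and compound 2 `COc1ccc(N/C=N/C2=C(C#N)C3C(N4CCCC4)CCCCN3C(=O)N2c2ccccc2)cc1` gives 37.2%; compound 2 and compound 3 lie within the scatter of each other.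

Compound 4 `N#CC1=C(NC(=O)c2ccccc2O)N(c2ccccc2)C(=O)N2CCCCC(N3CCCC3)C12` has not yet been measured. It differs from compound 1 in one place: (2-hydroxyphenyl)carbonyl in place of (pyrrolidin-1-yl)methyl on an amine nitrogen. The group that enters carries a six-membered aromatic ring, one hydrogen-bond donor and two acceptors, where the pyrrolidine ring of compound 1 offered no donor.

For the measured compounds named here, two measured steps bear on this change. The step of a number 10.6 percentage points higher from compound 1 to compound 2 (beyond the scatter) also exchanged the group on the double-bonded ring carbon for one holding a six-membered aromatic ring, and the step of a number 10.3 percentage points higher from compound 1 to compound 3 (beyond the scatter) enlarged the saturated ring on that side of the molecule. Both moves away from compound 1 gave a modest rise, and the two altered compounds ended up within the scatter of each other. Going by the values given here, a modest rise of similar size is therefore expected for compound 4, although a group with a carbonyl and a hydroxyl has no direct precedent here, so the range is kept wide.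

The estimate for compound 4 in this assay is 35%, between 22% and 48%, which is expected to mean a step of a number 8.4 percentage points higher from compound 1 to compound 4 (within the scatter).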

Compound 4, a percentage reported as inhibition, in the whole organism at one dose (the size of the read-out at that dose, not a potency): 53.8%
Compound 4: middle estimate off by 18.8 percentage points, on the low side; measured number outside the range, above it.
By their numbers in this assay, from the lowest: compound 1; then compounds 3 and 2 (each within the scatter of the next); then compound 4.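

With (2-hydroxyphenyl)carbonyl on the amine nitrogen, this assay shows a number 27.2 percentage points higher from compound 1 to compound 4 (beyond the scatter), and the same change from the piperidine analogue gives a number 16.9 percentage points higher from compound 3 to compound 4 (beyond the scatter), so this position can carry a group very different from the (pyrrolidin-1-yl)methyl and (piperidin-1-yl)methyl groups seen before. A six-membered aromatic ring at this site is not enough on its own to reach this level, since compound 2 also holds such a ring in its group on the double-bonded ring carbon, and the data still show a number 16.6 percentage points higher from compound 2 to compound 4 (beyond the scatter). No measurement here explains the rise, so the result stands as an observation without a known cause.

The compounds shown do not separate the contribution of the carbonyl from that of the hydroxyl, and a plain benzoyl group or an acetyl group on the same amine nitrogen would help to tell them apart. Each number also comes from a single dose, so how the order of these compounds would look at other doses remains open.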